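A Methyl Group Added to Compound 1

The compounds below may be only part of what the source reports. "The series", "measured", "known", "first", "only" and "open" are said of these compounds alone.

Of the compounds shown here, three sharing one core have been measured so far in a functional assay on CWR22R cells (Homo sapiens) for inhibition (a higher number here means a weaker inhibitor, a lower number a stronger inhibitor), and they give a first view of this series. Compound 1 `CCn1c(=O)/c(=C2\Sc3ccccc3N2C)s/c1=C\c1ccncc1Nc1ccccc1F` gives 300 nM and compound 2 `CCn1c(=O)/c(=C2\Sc3cc(F)ccc3N2C)s/c1=C\c1ccncc1Nc1ccccc1F` gives 150 nM while compound 3 `CCn1c(=O)/c(=C2\Sc3ccccc3N2C)s/c1=C\c1ccncc1Nc1cc(C)ccc1C` gives 1800 nM in the same test. Compound 1 therefore stands together with compound 2 and well apart from compound 3, which has the highest number of the three.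

Compound 4 `CCn1c(=O)/c(=C2\Sc3ccc(C)cc3N2C)s/c1=C\c1ccncc1Nc1ccccc1F` has not yet been measured. It differs from compound 1 by methyl in place of hydrogen on an aromatic carbon of a six-membered aromatic ring of carbon only.

Among the compounds with values here, two measured steps bear on this change. The closer one is a 2.0-fold lower number from compound 1 to compound 2 (0.30 log units; within the scatter) for fluoro in place of hydrogen on an aromatic carbon. The other is a 6.0-fold higher number from compound 1 to compound 3 (0.78 log units; beyond the scatter) for 2,5-dimethylphenyl in place of 2-fluorophenyl on a nitrogen on an aromatic ring, and it lies elsewhere in the molecule, so it says little here. Within the data shown here, no measured compound carries a methyl at the new place, which leaves the direction open. A step beyond the scatter is not expected in this assay for this small change. The expected outcome is a 1.2-fold lower number from compound 1 to compound 4 (0.08 log units; within the scatter) on this estimate. For compound 4 the estimated value is 250 nM with an expected range from 100 nM to 650 nM in this series.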

Compound 4, half-maximal inhibitory concentration: 150 nM
Compound 4: middle estimate off by 1.7-fold (0.22 log units), on the high side, and the stated range covers the measured number.
By their numbers in this assay, from the lowest: compounds 2, 4 and 1 (each within the scatter of the next); then compound 3.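

Placed on an aromatic carbon of the six-membered ring of carbon only, the methyl gives in this assay a 2.0-fold lower number from compound 1 to compound 4 (0.30 log units; within the scatter), so this position accepts a carbon group with no change that stands clear of the scatter. Within the data shown here, until this result, the only change on this ring was the fluoro of compound 2, so the step shows that a group with a heavier, carbon-based atom can also sit on this ring without a step beyond the scatter, unlike the change on the other aromatic ring that gave compound 3. Nothing among the data shown explains why the methyl is accepted here.

The compounds shown leave open how much room this carbon allows, since a single methyl says nothing about an ethyl, a methoxy, an amine or a carboxylic acid in the same place. They also leave open whether a methyl on this carbon and the fluoro of compound 2 would add up in one molecule, and whether the methyl would be accepted alongside the 2,5-dimethylphenyl of compound 3.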